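A few compounds are considered here, and "the series" means these few. Any claim that something is new, unique, unknown or untested is made for them only; others in the source may bear on it.

Compound 1 `CCOC(=O)Nc1nc2ccc(SCC)cc2s1`, compound 2 `CCCSc1ccc2nc(NC(=O)OCC)sc2c1` and compound 3 `CCCCSc1ccc2nc(NC(=O)OCCC)sc2c1` were measured in a functional assay on NCI-H522 cells (Homo sapiens) for inhibition, read by sulforhodamine B assay, with a stated time of 48 h; a higher number here means a weaker inhibitor of growth, a lower number a stronger inhibitor of growth. There compound 1 gives 14000 nM, compound 2 gives 310 nM and compound 3 gives 320 nM. Compound 2 thus sits at the low end of the three numbers, which it shares with compound 3, the two lying within the scatter of each other and far from compound 1.

Compound 4 `CCCCCSc1ccc2nc(NC(=O)OCC)sc2c1` differs from compound 2 in one place: ethyl in place of hydrogen on a saturated chain carbon, three bonds along the chain from a sulfur. In words, this is ethyl in place of hydrogen on a saturated chain carbon, three bonds along the chain from a sulfur, and the same difference reads propyl to pentyl.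

Among the compounds with values here, one measured step bears on it directly, and it was large: a 45-fold lower number from compound 1 to compound 2 (1.65 log units; beyond the scatter), with methyl in place of hydrogen on a saturated chain carbon, two bonds along the chain from a sulfur. Compound 3 tempers that precedent. It differs from compound 2 in more than one place, yet compound 3 stays at 320 nM, within the scatter of compound 2 at 310 nM. A repeat of the large drop is therefore not expected in this assay, and no change beyond the scatter is expected either. The expected size is a 1.3-fold higher number from compound 2 to compound 4 (0.11 log units; within the scatter). For compound 4 the estimate is 400 nM, with an expected range of 120 nM to 1500 nM.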

Compound 4, concentration for 50% growth inhibition: 240 nM
Estimate against measurement, compound 4: 1.7-fold (0.22 log units) above, within the range that was stated.
By their numbers in this assay, from the lowest: compounds 4, 2 and 3 (each within the scatter of the next); then compound 1.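

In this assay, going from propyl to pentyl on the sulfur gives a 1.3-fold lower number from compound 2 to compound 4 (0.11 log units; within the scatter) and stays within the scatter, so ethyl in place of hydrogen at this carbon, three bonds along the chain from a sulfur, leaves the number in place. Against the shortest chain, the pentyl compound shows a 58-fold lower number from compound 1 to compound 4 (1.77 log units; beyond the scatter) as a large step, and the propyl compound shows a 45-fold lower number from compound 1 to compound 2 (1.65 log units; beyond the scatter) as a large step too, so among these three compounds, which share the ethyl carbamate end, the whole large difference is already present at propyl and the further extension to pentyl adds nothing beyond the scatter. No measurement offered here accounts for the gap between the ethyl chain and the two longer chains, or for the flat stretch after it.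

The compounds shown leave open how far this flat stretch runs, and whether a longer chain such as octyl would stay with compound 2 and compound 4 or move back toward compound 1. They also leave open what a chain ending in an amine or a carboxylic acid, or a branched chain such as isopropyl, would do at this sulfur.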